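The compounds below may be only part of what the source reports. "The series", "measured", "known", "first", "only" and "open" are said of these compounds alone.

Working notes on the series in an in vitro assay on CHO cells for displacement of a labelled ligand from Bombesin receptor subtype-3 (Homo sapiens), read by scintillation counting, with a stated time of 2 h; on this read-out higher numbers stand for weaker inhibition and lower numbers for stronger inhibition. Among the measured compounds shown here, compound 1 `CCC(C)(C)Cc1c[nH]c(CCc2ccc(-n3ccnn3)cc2)n1` gives 390 nM, which is the higher of the two numbers measured so far; the only neighbour is compound 2 `CCC(C)(C)Cc1c[nH]c(CCc2ccc(-c3cnsc3)cc2)n1`, which gives 10 nM, a step of a 39-fold lower number from compound 1 to compound 2 (1.59 log units; beyond the scatter). For the measured compounds named here, that step comes from a different replacement, 1,2-thiazol-4-yl in place of 1H-1,2,3-triazol-1-yl, so it shows only that the group at this position can move the number a great deal, not how a second triazole isomer will behave.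

Compound 3 `CCC(C)(C)Cc1c[nH]c(CCc2ccc(-n3cncn3)cc2)n1` differs from compound 1 by 1H-1,2,4-triazol-1-yl in place of 1H-1,2,3-triazol-1-yl on an aromatic carbon. Going by the values given here, no measured step swaps one triazole for another, so the direction is not fixed by the data. The number for compound 3 is expected to stay close to compound 1, with the expected step of a 1.3-fold lower number from compound 1 to compound 3 (0.11 log units; within the scatter) likely within the scatter. The estimate for compound 3 is 300 nM, in the range 80 nM to 1200 nM.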

Compound 3, half-maximal inhibitory concentration: 340 nM
The estimate for compound 3 lay 1.1-fold (0.05 log units) below the measured number; measured number inside the range.
By their numbers in this assay, from the lowest: compound 2; then compounds 3 and 1 (each within the scatter of the next).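

In this assay, exchanging 1H-1,2,3-triazol-1-yl for 1H-1,2,4-triazol-1-yl on the aromatic carbon gives a 1.1-fold lower number from compound 1 to compound 3 (0.06 log units; within the scatter), so this rearrangement of the same ring atoms produces no readable change at this position. The large gap to the 1,2-thiazol-4-yl group now appears with a second triazole, as a 34-fold higher number from compound 2 to compound 3 (1.53 log units; beyond the scatter), so compound 2 stands apart from both triazoles and not from one isomer alone. No supporting data bear on either step.

Both triazoles are joined through ring nitrogen and the 1,2-thiazol-4-yl group through ring carbon, so the compounds shown do not separate the effect of the ring atoms from that of the attachment point. A 1H-pyrazol-1-yl or thiophen-3-yl group would bear on that question, while an amine or a carboxylic acid at this position remains unaddressed.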